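Phenyl added to compound 3, starting from a limit

The source may hold more compounds than are shown below. What is called first, only, known or untested is meant among the compounds shown, and "the series" means these compounds.

In a functional assay on CUTLL1 cells (Homo sapiens) for inhibition, read by resazurin assay, with a stated time of 48 h, in the presence of a further agent that is not named here (on this read-out lower numbers stand for an effect already at smaller amounts and higher numbers for an effect only at larger amounts of compound), compound 1 `Nc1ncc(-c2ccccc2)c(C2CC2)n1` gives > 100000 nM, which is a limit. Compound 2 `CC(C)c1nc(N)ncc1-c1ccncc1` gives > 100000 nM, also a limit. Compound 3 `Nc1ncc(-c2ccncc2)cn1` gives > 100000 nM, again a limit and no number. All three readings stand at the limit of > 100000 nM in this assay, at which 3 of the 3 values shown sit. Within the data shown here, the only measured step, a step that the two limits leave unreadable from compound 2 to compound 3, supplies no size. Compound 4 `Nc1ncc(-c2ccncc2)c(-c2ccccc2)n1` arises through (phenyl in place of hydrogen on an aromatic carbon), with phenyl in place of hydrogen, ortho to a pyridin-4-yl group. No measured step sizes this change, so any readable step can only run toward lower numbers. The expected change is modest, an estimated at least 3.3-fold lower number from compound 3 to compound 4 (0.52 log units; beyond the scatter). For compound 4 the estimated value is 30000 nM, with an expected range of 3000 nM to 100000 nM.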

Compound 4, half-maximal effective concentration: > 100000 nM
Compound 4: a limit, no number; the forecaster's own chance of this, stated with the estimate: 50%; middle value at least 3.3-fold (0.52 log units) away from the limit.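

No step can be read from compound 3 to compound 4 or from compound 2 to compound 4, since each pair has only limits: the limit of > 100000 nM in this assay, at which 4 of the 4 values shown sit.

The compounds shown leave open whether any change to the shared core yields a number rather than a limit.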